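The source may report more compounds than this note shows. Statements on the series, on what has been measured and on what is new or still open speak of the compounds shown alone.

Compound 1 `CC(C)(C)OC(=O)NCCCCN(CCCN(Cc1ccccc1)Cc1ccccc1)CCCN(Cc1ccccc1)Cc1ccccc1` carries a tert-butoxycarbonyl group on the terminal amine of its chain, and in an ADME assay on RAW264.7 cells (Mus musculus) for cytotoxicity, read by resazurin assay, with a stated time of 48 h (a lower number here means that less compound is tolerated, a higher number that more compound is tolerated), compound 1 gives 12500 nM. Compound 2 `CC(C)(C)OC(=O)NCCCCN(CCCN(Cc1ccc(F)cc1)Cc1ccc(F)cc1)CCCN(Cc1ccc(F)cc1)Cc1ccc(F)cc1` keeps that protected amine on a different core; the difference between the two cores is not broken down here. In this assay compound 2 gives 12000 nM, a value that sits within the usual scatter of what compound 1 shows.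

Compound 3 `NCCCCN(CCCN(Cc1ccccc1)Cc1ccccc1)CCCN(Cc1ccccc1)Cc1ccccc1` is the deprotected partner of compound 1: the change is hydrogen in place of tert-butoxycarbonyl on an amine nitrogen. That change made a 10-fold lower number from compound 1 to compound 3 (1.02 log units; beyond the scatter), so compound 3 gives 1200 nM in this assay, a number well beyond the scatter of repeated measurements.

Compound 4 `NCCCCN(CCCN(Cc1ccc(F)cc1)Cc1ccc(F)cc1)CCCN(Cc1ccc(F)cc1)Cc1ccc(F)cc1` has not yet been measured. Going by the values given here, its relation to compound 2 is hydrogen in place of tert-butoxycarbonyl on an amine nitrogen, the same change as the one from compound 1 to compound 3, at the same kind of place, an amine nitrogen whose other neighbours are saturated chain carbon. Among the compounds with values here, because the one earlier instance of this change gave a 10-fold lower number from compound 1 to compound 3 (1.02 log units; beyond the scatter), and because compound 2 starts from 12000 nM, the step from compound 2 to compound 4 in this assay is expected to be a 10-fold lower number from compound 2 to compound 4 (1.00 log units; beyond the scatter). Within the data shown here, on that basis compound 4 is estimated to give 1200 nM in this assay, with a plausible range from 500 nM to 3000 nM, the uncertainty reflecting that only a single precedent exists and the cores differ.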

Compound 4, half-maximal cytotoxic concentration: 1500 nM
The estimate for compound 4 lay 1.3-fold (0.10 log units) below the measured number; measured number inside the range.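

In this assay, hydrogen in place of tert-butoxycarbonyl on the amine nitrogen gave an 8.0-fold lower number from compound 2 to compound 4 (0.90 log units; beyond the scatter), and the step carried over from the core of compound 1 to the core of compound 2 with no difference that can be told apart: the same change on two cores in this assay, a 10-fold lower number (1.02 log units; beyond the scatter) from compound 1 to compound 3 and an 8.0-fold lower number (0.90 log units; beyond the scatter) from compound 2 to compound 4, 1.3-fold (0.11 log units) apart, within the scatter of two such steps

Across these two pairs, then, the change from (tert-butoxycarbonyl)amino to amino goes with less compound being tolerated, the size of the step holds on both cores, and neither pair goes against this. Two pairs do not show that the step would hold on other cores, and they do not tell whether it follows from losing the tert-butoxycarbonyl group or from gaining the free amino group.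

The compounds shown leave open whether an acetyl group or a methyl group on that amine nitrogen, or a longer chain carrying the amino group, would give a step of similar size. They also leave open how the change behaves on a third core, and whether a step of this size would appear in any read-out other than this assay.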